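This account rests on a few compounds, and the source may have more. Where it says the series, first, only, none or still open, it means among the compounds named here.

Compound 1 `O=C1CCC[C@@H]([C@H]2C[C@@H]2c2ccccc2)O1` and its mirror image, compound 2 `O=C1CCC[C@H]([C@@H]2C[C@H]2c2ccccc2)O1`, were both tested in a functional assay on A549 cells (Homo sapiens) for antiproliferative activity, read by luminescence and CellTiter-Glo, with a stated time of 48 h; a higher number here means a weaker inhibitor, a lower number a stronger inhibitor. Compound 1 gives > 100000 nM, which is a limit of the assay and not a number. Compound 2 gives > 100000 nM, which is also a limit, so its position can be stated only as that limit. Compound 3 `O=C1CCC[C@H]([C@H]2C[C@@H]2c2ccccc2)O1` differs from compound 2 in shape alone: the two compounds have the same atoms and bonds and differ only in configuration as drawn: 2 of 3 stereo elements differ; a stereocentre at a saturated ring carbon is drawn R in compound 2 and S in compound 3; a stereocentre at a saturated ring carbon is drawn R in compound 2 and S in compound 3. Going by the values given here, the one measured step that bears on this change is a step that the two limits leave unreadable from compound 1 to compound 2. It offers no size to carry forward, but inverting every stereocentre still left both compounds at the limit of > 100000 nM in this assay, at which 2 of the 2 values shown sit. No clear step is therefore expected in this assay, and compound 3 will probably be reported as a limit too. The expected change is a step that the limit leaves unreadable from compound 2 to compound 3. The estimated value for compound 3 is 120000 nM, with an expected range of 40000 nM to 300000 nM.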

Compound 3, half-maximal inhibitory concentration: > 100000 nM
Compound 3 was reported as a limit (the forecaster's own chance of this, stated with the estimate: 85%); the middle value lies beyond the limit too.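

The steps among compound 1, compound 2 and compound 3 cannot be read, as each result is a limit and not a number: the limit of > 100000 nM in this assay, at which 3 of the 3 values shown sit. On these data alone, whether configuration changes the activity of the shared core at all remains open, as does the true strength of each compound.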